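A few compounds are considered here, and "the series" means these few. Any claim that something is new, unique, unknown or untested is made for them only; others in the source may bear on it.

Working notes on the ester series. Compound 2, `CNc1nc(C#Cc2ccc(Cl)s2)nc2c1ncn2[C@H]1[C@H](O)[C@H](O)[C@]2(C(=O)OC(C)C)C[C@H]12`, carries the isopropyl ester and in an assay on HEK293 cells for binding affinity to sodium-dependent dopamine transporter (Homo sapiens), read by scintillation counting and radioligand binding, with stated times of 10 min and 90 min, tested at 10 uM (on this read-out higher numbers stand for more inhibition at the one concentration tested (going by the name of the read-out) and lower numbers for less inhibition), compound 2 gives 36%. Among the measured compounds shown here, this is the only number recorded for the series: compound 1, `CCCOC(=O)[C@@]12C[C@@H]1[C@@H](n1cnc3c(NC)nc(C#Cc4ccc(Cl)s4)nc31)[C@H](O)[C@@H]2O`, the propyl ester, is reported in this assay as "not active" (no number reported), without a figure, so no step between measured compounds can be drawn and compound 2 stands alone on the numbers. Compound 3, `CCCCOC(=O)[C@@]12C[C@@H]1[C@@H](n1cnc3c(NC)nc(C#Cc4ccc(Cl)s4)nc31)[C@H](O)[C@@H]2O`, differs from compound 2 by butyl in place of isopropyl on an oxygen next to a carbonyl group. Nothing measured speaks to this particular change, and the two ester variants already seen give no direction to lean on. A small downward step is expected, a number 11 percentage points lower from compound 2 to compound 3 (beyond the scatter), though a result within the scatter of compound 2 is equally plausible. For compound 3 in this assay the estimate is 25%, with a range from 5% to 50%.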

Compound 3, a percentage reported as inhibition, at one concentration (the size of the read-out at that concentration, not a potency): "not active" (no number reported)
No number was reported for compound 3; there is nothing to compare the estimate with.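

Among the compounds shown here, compound 3 carries no number in this assay and, like compound 1, gives no step against compound 2 that can be read. The compounds shown leave open how the butyl and isopropyl esters compare on this read-out. No supporting measurement bears on this result.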